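The compounds below may be only part of what the source reports. "The series", "measured", "known", "first", "only" and "open" are said of these compounds alone.

In a toxicity assay on Huh-7 cells (Homo sapiens) for cytotoxicity, read by MTT assay, with a stated time of 72 h (on this read-out lower numbers stand for higher toxicity in this test and higher numbers for lower toxicity in this test), compound 3 `Clc1ccc2c(NCCNc3ccc(Br)cc3)ccnc2c1` gives > 100 ug/mL, a limit of the assay rather than a number. Compound 1 `COc1ccc(NCCNc2ccnc3cc(Cl)ccc23)cc1` gives > 100 ug/mL in this assay, also a limit. Compound 2 `Clc1ccc(NCCNc2ccnc3cc(Cl)ccc23)c(Cl)c1` gives > 100 ug/mL in this assay, again a limit. Compound 3 therefore cannot be ranked against the other two, since all three values rest at the limit of > 100 ug/mL in this assay, at which 3 of the 3 values shown sit. For the measured compounds named here, the only single-point step among the measured compounds, from compound 1 to compound 3, reads a step that the two limits leave unreadable from compound 1 to compound 3. Compound 4 `Fc1ccc(NCCNc2ccnc3cc(Cl)ccc23)cc1` differs from compound 3 by fluoro in place of bromo on an aromatic carbon. Going by the values given here, because the limit of > 100 ug/mL in this assay, at which 3 of the 3 values shown sit, holds every value measured so far, compound 4 is expected to show a step that the limit leaves unreadable from compound 3 to compound 4 and to sit at about 150 ug/mL, most probably from 80 ug/mL to 300 ug/mL.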

Compound 4, half-maximal cytotoxic concentration: > 100 ug/mL
Compound 4 was reported as a limit (the forecaster's own chance of this, stated with the estimate: 85%); the middle value does not contradict the limit.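

No step can be read from compound 3 or compound 1 to compound 4, since each value is only a limit: the limit of > 100 ug/mL in this assay, at which 4 of the 4 values shown sit.

The compounds shown leave open how these four rank in this assay, and whether the changed aromatic group affects toxicity there.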